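The source may hold more compounds than are shown below. What is called first, only, known or untested is meant among the compounds shown, and "the series" means these compounds.

Compounds measured in an ADME assay on NCI/ADR-RES cells (Homo sapiens) for cytotoxicity, read by MTT assay, with a stated time of 48 h; a lower number here means a stronger inhibitor, a higher number a weaker inhibitor:
- compound 1 `C=C1[C@H](OC(C)=O)[C@H]2[C@@H](OC(=O)c3ccccc3)[C@@H](C)C[C@]2(OC(C)=O)C(=O)[C@@H](C)/C=C/C(C)(C)C(=O)[C@H](OC(C)=O)[C@H]1OC(C)=O`: > 100000 nM, a limit
- compound 2 `C=C1[C@H](OC(C)=O)[C@H]2[C@@H](OC(=O)c3ccccc3)[C@@H](C)C[C@]2(OC(C)=O)C(=O)[C@@H](C)/C=C/C(C)(C)C(=O)[C@H](O)[C@H]1OC(C)=O`: > 100000 nM, a limit
- compound 3 `C=C1[C@H](O)[C@H]2[C@@H](OC(=O)c3ccccc3)[C@](C)(OC(C)=O)C[C@]2(O)[C@H](OC(C)=O)[C@@H](C)/C=C/C(C)(C)C(=O)[C@H](OC(C)=O)[C@H]1OC(C)=O`: > 100000 nM, a limit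

Compound 2 has no numerical value in this assay, only the limit > 100000 nM. The two other compounds offer no numerical reference either. Among the compounds with values here, the series so far reads as the limit of > 100000 nM in this assay, at which 3 of the 3 values shown sit.

The step followed here leads to compound 4 `C=C1[C@H](OC(C)=O)CC(=O)C(C)(C)/C=C/[C@H](C)C(=O)[C@@]2(OC(C)=O)C[C@H](C)[C@H](OC(=O)c3ccccc3)[C@@H]2[C@H]1OC(C)=O`. The change is hydrogen in place of hydroxy on a saturated ring carbon.

Within the data shown here, one measured step bears on it: a step that the two limits leave unreadable from compound 1 to compound 2, with hydrogen in place of acetyl on an oxygen on a saturated carbon. That oxygen is the one that leaves on the way to compound 4. Neither end of that step is a number, so it provides no size or direction to carry over.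

No readable step in either direction is therefore expected in this assay, and compound 4 is expected to report the same limit as the measured compounds. The step expected is a number no higher from compound 2 to compound 4 (the limit leaves the size open). For compound 4 the estimated value is 100000 nM, with an expected range of 30000 nM to 200000 nM.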

Compound 4, half-maximal inhibitory concentration: 39300 nM
Compound 4: the middle estimate sits 2.5-fold (0.41 log units) above what was measured; measured number inside the range.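

In this assay the series now holds its first number in place of a limit, and that number belongs to the compound without oxygen at this saturated ring carbon. Hydrogen in place of hydroxy at this carbon gives an at least 2.5-fold lower number from compound 2 to compound 4 (0.40 log units; beyond the scatter), and hydrogen in place of acetoxy at the same carbon gives an at least 2.5-fold lower number from compound 1 to compound 4 (0.40 log units; beyond the scatter). So loss of the oxygen moves the series off its limit from either starting group, though both sizes remain open-ended, and the step between the acetoxy and hydroxy compounds cannot be read: the limit of > 100000 nM in this assay, at which 3 of the 4 values shown sit.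

From the compounds shown here alone, with a single number, it stays open whether the gain depends on the absence of oxygen at this carbon or whether another small group there, such as an amine or a fluorine, would also give a readable value. Going by these compounds, it also stays open whether the same replacement would give a readable step at the other acetoxy positions on the shared core, or how far a longer chain in place of the benzoate would shift the value of compound 4.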